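A few compounds are considered here, and "the series" means these few. Any claim that something is new, unique, unknown or untested is made for them only; others in the source may bear on it.

The measured compounds and their values:

Compound 1 `C/C(=N\OC(c1ccc(OCc2ccc3ccccc3n2)cc1)C1CCCC1)C(=O)O`, which in a functional assay for inhibition of Polyunsaturated fatty acid 5-lipoxygenase (Homo sapiens) (on this read-out lower numbers stand for stronger inhibition and higher numbers for weaker inhibition), gives 16 nM.
Compound 2 `C/C(=N\OC(c1ccc(OCc2ccc3ccccc3n2)cc1)C1CCCCCC1)C(=O)O`, which in this assay gives 13 nM.
Compound 3 `C/C(=N\OC(CCCc1ccc(F)cc1)c1ccc(OCc2ccc3ccccc3n2)cc1)C(=O)O`, which in this assay gives 9 nM.

Compound 3 has the lowest of the three numbers, but its separation from the others is small: a 1.4-fold lower number from compound 2 to compound 3 (0.16 log units; within the scatter) and a 1.8-fold lower number from compound 1 to compound 3 (0.25 log units; within the scatter), so no ordering among the three can be claimed. The same holds for a 1.2-fold lower number from compound 1 to compound 2 (0.09 log units; within the scatter).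

Compound 4 `C/C(=N\OCc1ccc(OCc2ccc3ccccc3n2)cc1)C(=O)O` is the compound still to be measured. The change from compound 3 is hydrogen in place of 3-(4-fluorophenyl)propyl on a saturated chain carbon bound to an aromatic carbon and an oxygen. None of the three measured steps bears on this change directly, since each of them swaps one substituent at that carbon for another, whereas here the substituent is removed altogether and only hydrogen remains. All three swaps lay within the scatter, which tells nothing about what removal does. For the measured compounds named here, with no direct precedent, a modest weakening is expected, a 3.3-fold higher number from compound 3 to compound 4 (0.52 log units; beyond the scatter), with wide uncertainty. Compound 4 is therefore estimated at 30 nM in this assay, within a range from 8 nM to 150 nM.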

Compound 4, half-maximal inhibitory concentration: 1400 nM
For compound 4 the middle estimate is 47-fold (1.67 log units) below the measured one, and the stated range ends below it.
By their numbers in this assay, from the lowest: compounds 3, 2 and 1 (each within the scatter of the next); then compound 4.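

In this assay the substituent on the saturated chain carbon bound to an aromatic carbon and an oxygen proves to matter a great deal, which the swaps among cyclopentyl, cycloheptyl and 3-(4-fluorophenyl)propyl could not show: with hydrogen there, the data give a 160-fold higher number from compound 3 to compound 4 (2.19 log units; beyond the scatter) and also a 110-fold higher number from compound 2 to compound 4 (2.03 log units; beyond the scatter) and an 88-fold higher number from compound 1 to compound 4 (1.94 log units; beyond the scatter) as large steps of similar size. Three different groups thus sit within the scatter of one another, and all three lie far from hydrogen at this carbon. Nothing available accounts for this large loss.

As far as these compounds go, whether a single methyl group at this carbon would be enough to recover the low numbers, or whether a ring or a longer chain is required, remains open. Also open, from the compounds shown here alone, is how an amine or a hydroxyl group at the end of such a chain would fare.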